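Chain-end amine swap on the quinoline ether series

The source may hold more compounds than are shown below. What is called first, only, known or untested is meant among the compounds shown, and "the series" means these compounds.

Compound 3 `COc1cc2c(Oc3ccc(NC(=O)c4nn(-c5cccc(F)c5)c(=O)cc4C)cc3F)ccnc2cc1OCCCN1CCCC1` gives 280 nM in a functional assay on NCI-H460 cells (Homo sapiens) for inhibition, read by MTT assay, with a stated time of 72 h (on this read-out lower numbers stand for stronger inhibition and higher numbers for weaker inhibition), and stands second highest of the three numbers. Compound 2 `COc1cc2c(Oc3ccc(NC(=O)c4nn(-c5ccccc5C(F)(F)F)c(=O)cc4C)cc3F)ccnc2cc1OCCCN1CCCC1` gives 210 nM in this assay, and the step of a 1.3-fold higher number from compound 2 to compound 3 (0.12 log units; within the scatter) is within the scatter. Compound 1 `COc1cc2c(Oc3ccc(NC(=O)c4nn(-c5ccccc5C)c(=O)cc4C)cc3F)ccnc2cc1OCCCN1CCN(C)CC1` gives 3420 nM in this assay, beyond the scatter from compound 3. Compound 4 `COc1cc2c(Oc3ccc(NC(=O)c4nn(-c5cccc(F)c5)c(=O)cc4C)cc3F)ccnc2cc1OCCCN1CCN(C)CC1` carries the change (4-methylpiperazin-1-yl in place of pyrrolidin-1-yl on a saturated chain carbon, three bonds along the chain from an oxygen on an aromatic ring). For the measured compounds named here, no measured step isolates this change: compound 1 has the same 4-methylpiperazin-1-yl chain end but also a different aryl group on the aromatic nitrogen, so its value and that of compound 3 show only a combined difference. The step of a 2.1-fold higher number from compound 3 to compound 4 (0.33 log units; beyond the scatter) is therefore expected to lean toward a higher number, with wide uncertainty. Compound 4 is estimated at 600 nM in this assay, within 150 nM to 2500 nM.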

Compound 4, half-maximal inhibitory concentration: 260 nM
For compound 4 the middle estimate is 2.3-fold (0.36 log units) above the measured one, within the range that was stated.
By their numbers in this assay, from the lowest: compounds 2, 4 and 3 (each within the scatter of the next); then compound 1.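

With 3-fluorophenyl held fixed in this assay, the chain-end swap gives a 1.1-fold lower number from compound 3 to compound 4 (0.03 log units; within the scatter), so 4-methylpiperazin-1-yl and pyrrolidin-1-yl are not told apart at this position. With 4-methylpiperazin-1-yl held fixed, the aryl swap gives a 13-fold lower number from compound 1 to compound 4 (1.12 log units; beyond the scatter), which places the large gap with the group on the aromatic nitrogen and not with the chain end. No supporting evidence bears on either step.

As far as these compounds go, whether morpholin-4-yl or dimethylamino at the chain end would give a similar number stays open. So does whether the chain-end result holds with 2-methylphenyl or 2-(trifluoromethyl)phenyl on the aromatic nitrogen.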